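A few compounds are considered here, and "the series" means these few. Any claim that something is new, unique, unknown or untested is made for them only; others in the source may bear on it.

Working notes on the series. Compound 2, `CC1=NC(C)=C([N+](=O)[O-])C(c2ccccn2)/C1=C(\O)OCC(C)C`, was tested in a functional assay (cardiac atrium) for agonist activity, with Cavia porcellus as the target (on this read-out higher numbers stand for an effect only at larger amounts of compound and lower numbers for an effect already at smaller amounts), and gives 9100 nM. Going by the values given here, the only other measured member is compound 1, `CC1=NC(C)=C([N+](=O)[O-])C(c2cccnc2)/C1=C(\O)OC(C)C`, which in this assay gives 28500 nM. Among the compounds with values here, compound 2 thus stands with the lowest number of the two, and the gap to compound 1 lies beyond the scatter; compound 1 and compound 2 differ in more than one place, so no single step between them can be read.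

The next compound, compound 3, `CC1=NC(C)=C([N+](=O)[O-])C(c2cccnc2)/C1=C(\O)OCC(C)C`, is unmeasured. The change from compound 2 is pyridin-3-yl in place of pyridin-2-yl on a saturated ring carbon. Compound 3 shares the pyridin-3-yl group with compound 1, which in this assay gives 28500 nM, and this is the only point of reference for the change. The expected step toward a higher number is estimated as a 2.2-fold higher number from compound 2 to compound 3 (0.34 log units; beyond the scatter). This expectation carries wide uncertainty. Compound 3 is accordingly expected to give about 20000 nM in this assay, with a range of 6000 nM to 60000 nM.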

Compound 3, half-maximal effective concentration: 1740 nM
Compound 3: middle estimate off by 11-fold (1.06 log units), on the high side; measured number below the stated range.
By their numbers in this assay, from the lowest: compound 3; then compound 2; then compound 1.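

In this assay the saturated ring carbon turns out to respond to the mere placement of the nitrogen within the pyridine ring: pyridin-3-yl in place of pyridin-2-yl gives a 5.2-fold lower number from compound 2 to compound 3 (0.72 log units; beyond the scatter) and so lies beyond the scatter, although the two groups have identical counts of atoms, donors and acceptors. With pyridin-3-yl held fixed, the group on the oxygen can now be read on its own as well, since isobutyl in place of isopropyl gives a 16-fold lower number from compound 1 to compound 3 (1.21 log units; beyond the scatter) and this large step exceeds the modest one at the ring carbon in printed size. Nothing at hand gives a measured property that would account for either step.

Still open, going by these compounds, is whether pyridin-4-yl or a plain phenyl group on the saturated ring carbon would carry the number lower or higher than pyridin-3-yl does. Also open, on these data alone, are whether a longer chain such as n-pentyl on the oxygen would extend the step seen with isobutyl, and whether the two changes would combine in the same way with pyridin-2-yl and isopropyl together.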